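Swapping the Methoxy for a Methyl on the Pyridine

The source may report more compounds than this note shows. Statements on the series, on what has been measured and on what is new or still open speak of the compounds shown alone.

Measured so far, all in a functional assay on the whole organism (blood) with Rattus norvegicus as the target, with stated times of 24 h and 1 h, at a dose of 5 mg/kg by the intraperitoneal route; a higher number here means a stronger effect of the compound at the dose given, a lower number a weaker effect:
compound 1 `O=C(NC1CCCCC1)NS(=O)(=O)N1CCC(CCNC(=O)C(F)(F)F)CC1`: 13%
compound 2 `O=C(NC1CCCCC1)NS(=O)(=O)N1CCC(CCNC(=O)c2csnn2)CC1`: 19%
compound 3 `COc1ncccc1C(=O)NCCC1CCN(S(=O)(=O)NC(=O)NC2CCCCC2)CC1`: 33%

Compound 3 stands highest of the three. Its lead over compound 2 is a number 14 percentage points higher from compound 2 to compound 3 (beyond the scatter), and over compound 1 it is a number 20 percentage points higher from compound 1 to compound 3 (beyond the scatter), both beyond the scatter; compound 1 and compound 2 sit within the scatter of each other, a number 6 percentage points higher from compound 1 to compound 2 (within the scatter).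

Compound 4 `Cc1ncccc1C(=O)NCCC1CCN(S(=O)(=O)NC(=O)NC2CCCCC2)CC1` is yet to be measured. It differs from compound 3 in one place: methyl in place of methoxy on an aromatic carbon. Among the compounds with values here, no measured pair shows this change; the steps seen so far replace the whole group on the carbonyl carbon and keep the shared core fixed. They show that the group on that carbonyl carbon can move the read-out in this assay by a modest amount, but they say nothing about trading a methoxy for a methyl on the aromatic carbon of the pyridine. Within the data shown here, with no direct precedent, a small change of this kind is expected to stay within the scatter, leaning slightly downward.

Compound 4 is therefore estimated to give about 28%, between 15% and 42%, a step of a number 5 percentage points lower from compound 3 to compound 4 (within the scatter) that is expected to lie within the scatter.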

Compound 4, a percentage reported as activity, at one dose (the size of the read-out at that dose, not a potency): 16%
Compound 4: the middle estimate sits 12 percentage points above what was measured; the measured number falls inside the stated range.
By their numbers in this assay, from the lowest: compounds 1, 4 and 2 (each within the scatter of the next); then compound 3.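

In this assay the group on the aromatic carbon next to the ring nitrogen matters on its own: with everything else in the molecule unchanged, methyl in place of methoxy gives a number 17 percentage points lower from compound 3 to compound 4 (beyond the scatter) and this takes away the lead that compound 3 held. The pyridine ring alone therefore does not carry that lead, since a number 3 percentage points lower from compound 2 to compound 4 (within the scatter) and a number 3 percentage points higher from compound 1 to compound 4 (within the scatter) both lie within the scatter, leaving the 2-methylpyridin-3-yl group no clear of the 1,2,3-thiadiazol-4-yl or trifluoromethyl groups on the carbonyl carbon. No measurement available here explains why methoxy and methyl part ways at this position.

The compounds shown leave open whether the higher read-out belongs to methoxy alone or would also appear with an ethoxy, a hydroxyl, a chlorine or an amine on the same carbon. From the compounds shown here alone, each number is also the size of the effect at a single dose, so whether compound 3 would still give a stronger effect than compound 4 at other doses remains unknown.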